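Swapping Dimethylamino for Benzyloxy on a Weak Growth Inhibitor

The compounds below may be only part of what the source reports. "The series", "measured", "known", "first", "only" and "open" are said of these compounds alone.

Three measured compounds share one core. Compound 1 `CN(C)c1ccc(/C=C(/SCc2ccc(Cl)cc2Cl)C(=O)c2ccc(Cl)cc2)cc1` carries a dimethylamino group and a (2,4-dichlorobenzyl)sulfanyl group. In a functional assay on DU-145 cells (Homo sapiens) for inhibition, read by trypan blue exclusion, with a stated time of 96 h (a lower number here means a stronger inhibitor of growth, a higher number a weaker inhibitor of growth), compound 1 gives 50000 nM, the higher of the two numbers measured. Compound 2 `O=C(/C(=C\c1c[nH]c2ccc(Br)cc12)SCc1ccc(Cl)cc1Cl)c1ccc(Cl)cc1` gives 10000 nM in this assay, a change of a 5.0-fold lower number from compound 1 to compound 2 (0.70 log units; beyond the scatter). Compound 3 `CN(C)c1ccc(/C=C(\C(=O)c2ccc(Cl)cc2)S(=O)(=O)c2ccc(Br)cc2)cc1` reaches only a limit of the assay, > 100000 nM, in this assay. The step of an at least 2.0-fold higher number from compound 1 to compound 3 (0.30 log units; that floor lies within the scatter) therefore cannot be sized beyond its floor.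

Compound 4 `O=C(/C(=C\c1ccc(OCc2ccccc2)cc1)SCc1ccc(Cl)cc1Cl)c1ccc(Cl)cc1` differs from compound 1 in one place: benzyloxy in place of dimethylamino on an aromatic carbon. Within the data shown here, no measured step changes this group alone. The closest comparison is the exchange of the whole aryl group, a 5.0-fold lower number from compound 1 to compound 2 (0.70 log units; beyond the scatter), which moved the number modestly lower; the change at the sulfur-bearing carbon, an at least 2.0-fold higher number from compound 1 to compound 3 (0.30 log units; that floor lies within the scatter), does not touch this position and ends in a limit. A swap confined to one substituent of the ring is expected to shift the number less than that full ring exchange did, and its direction cannot be read from the measured steps. Compound 4 is therefore expected to give 35000 nM in this assay, with a range from 8000 nM to 100000 nM. That estimate means an expected step of a 1.4-fold lower number from compound 1 to compound 4 (0.15 log units; within the scatter).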

Compound 4, concentration for 50% growth inhibition: 1000 nM
Compound 4: the middle estimate sits 35-fold (1.54 log units) above what was measured, and the stated range ends above it.
By their numbers in this assay, from the lowest: compound 4; then compound 2; then compound 1. At a limit, above all of these: compound 3.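

In this assay, among these compounds, the ring position named here turns out to matter far more than the earlier compounds could show: changing only this one substituent gives a 50-fold lower number from compound 1 to compound 4 (1.70 log units; beyond the scatter), whereas replacing the whole aryl group gave a 5.0-fold lower number from compound 1 to compound 2 (0.70 log units; beyond the scatter). So a single group on an aromatic carbon, para to a large group, can move the number further than that full exchange of the ring system did, and the move is towards stronger growth inhibition. The swap replaces a small group with no ring by a larger one that brings its own six-membered aromatic ring, while the hydrogen-bond donor and acceptor counts stay the same, but nothing measured here explains why the number fell so far.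

On these data alone, it remains open whether the oxygen or the added aromatic ring goes with the lower number: a methoxy group at this place would keep the oxygen without the ring, and a benzylamino group would keep the ring without the oxygen. A longer chain between the oxygen and the ring, such as phenethyloxy, would further show how much room for change this position allows.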